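Swapping the ring group on the weakest ester

The compounds below may be only part of what the source reports. "The series", "measured", "known", "first", "only" and "open" are said of these compounds alone.

In a functional assay on LFCl2A cells (Rattus norvegicus) for cytotoxicity (a higher number here means a weaker inhibitor, a lower number a stronger inhibitor), compound 1 (`CCCCCCCC/C=C\CCCCCCCC(=O)OC[C@H]1O[C@H](CC2=CCCCC2)C=CC1=O`) gives 80 nM and compound 2 (`CCCC(=O)OC[C@H]1O[C@H](CC2=CCCCC2)C=CC1=O`) gives 90 nM as its half-maximal inhibitory concentration, and these two values lie within the scatter of each other. Compound 3 (`CC/C=C\C/C=C\C/C=C\C/C=C\C/C=C\C/C=C\CCC(=O)OC[C@@H]1C=CC(=O)[C@@H](C2CCCC=C2C)O1`) gives 65000 nM in the same test, the highest of the three numbers and far beyond the scatter from both others, which makes it the weakest inhibitor so far. Compound 4 (`CC/C=C\C/C=C\C/C=C\C/C=C\C/C=C\C/C=C\CCC(=O)OC[C@@H]1C=CC(=O)[C@@H](CC2=CCCCC2)O1`) keeps the ester chain of compound 3 and carries (cyclohex-1-en-1-yl)methyl in place of 2-methylcyclohex-2-en-1-yl on a saturated ring carbon. The entering group is already present in compound 1, measured at 80 nM here, and in compound 2. Both differ from compound 3 in their ester chains and in how their cores are joined, so only part of that wide gap is expected to carry over. The expected change is a 22-fold lower number from compound 3 to compound 4 (1.34 log units; beyond the scatter) in this assay, a lowering beyond the scatter. Compound 4 is estimated at 3000 nM with an expected range from 200 nM to 40000 nM in this test.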

Compound 4, half-maximal inhibitory concentration: 30000 nM
Estimate against measurement, compound 4: 10-fold (1.00 log units) below; measured number inside the range.
By their numbers in this assay, from the lowest: compounds 1 and 2 (each within the scatter of the next); then compound 4; then compound 3.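

With the ester chain held the same, 2-methylcyclohex-2-en-1-yl gives way to (cyclohex-1-en-1-yl)methyl, and this assay shows a 2.2-fold lower number from compound 3 to compound 4 (0.34 log units; beyond the scatter). Among these compounds, this is the first reading of a change at this one place, the saturated ring carbon next to the ring oxygen. The two groups have the same atoms and the same counts of rings and double bonds, so a different joining of those atoms alone moves the number beyond the scatter, though only modestly, and compound 4 still gives 30000 nM. No measurement shown here explains why the number moves.

As far as these compounds go, whether this swap gives a step of similar size on a different ester chain remains open. So does what a benzyl group or a simple amine would do at this same ring carbon.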